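Ethyl to propyl on the pyridine-side amide of compound 1

The source may hold more compounds than are shown below. What is called first, only, known or untested is meant among the compounds shown, and "the series" means these compounds.

Within the data shown here, compound 1 `CCNC(=O)c1cc(Oc2ccc(NC(=O)c3cc4cccnc4n(-c4ccccc4F)c3=O)cc2)ccn1` is one of two compounds measured in a functional assay on NCI-H460 cells (Homo sapiens) for antiproliferative activity, read by MTT assay, with a stated time of 72 h; on this read-out lower numbers stand for stronger inhibition and higher numbers for weaker inhibition. In this assay compound 1 gives 1230 nM, the lowest of the two numbers, and its nearest neighbour is compound 2 `CCNC(=O)c1cc(Oc2ccc(NC(=O)c3cc4cccnc4n(-c4ccc(Br)cc4F)c3=O)cc2)ccn1`, which in this assay gives 1790 nM. Among the measured compounds shown here, the only measured step between them, a 1.5-fold higher number from compound 1 to compound 2 (0.16 log units; within the scatter), concerns bromo in place of hydrogen on an aromatic carbon and stays within the scatter.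

Compound 3 `CCCNC(=O)c1cc(Oc2ccc(NC(=O)c3cc4cccnc4n(-c4ccccc4F)c3=O)cc2)ccn1` has not yet been measured in this assay. It differs from compound 1 by methyl in place of hydrogen on a saturated chain carbon, two bonds along the chain from an amide-type nitrogen, so that ethylamino becomes propylamino. For the measured compounds named here, no measured step touches this part of the molecule; the one available step, a 1.5-fold higher number from compound 1 to compound 2 (0.16 log units; within the scatter), lies elsewhere and was itself within the scatter. The expectation is therefore a step of no size beyond the scatter, a 1.1-fold higher number from compound 1 to compound 3 (0.02 log units; within the scatter). Compound 3 is estimated to give 1300 nM in this assay, with a range from 600 nM to 2800 nM.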

Compound 3, half-maximal inhibitory concentration: 390 nM
For compound 3 the middle estimate is 3.3-fold (0.52 log units) above the measured one; measured number outside the range, below it.
By their numbers in this assay, from the lowest: compound 3; then compounds 1 and 2 (each within the scatter of the next).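

Lengthening ethylamino to propylamino gives a 3.2-fold lower number from compound 1 to compound 3 (0.50 log units; beyond the scatter) in this assay, so the end of this amide chain, which no earlier step had touched, is a place where the number responds to a small change. A single methyl in place of hydrogen on a saturated chain carbon, two bonds along the chain from an amide-type nitrogen, is enough to carry the step beyond the scatter, whereas the bromo change elsewhere in the molecule, a 1.5-fold higher number from compound 1 to compound 2 (0.16 log units; within the scatter) and stayed within it. Nothing available here accounts for the size or direction of the propyl step.

Going by these compounds, a single step does not define a trend, so it remains open whether a longer chain such as butyl, a branched isopropyl group or a cyclopropyl ring on the same amide nitrogen would lower the number further, hold it or raise it. On these data alone, it also remains open whether the propylamino gain carries over to the bromo-bearing compound 2 or holds only on the core of compound 1.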